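The compounds below may be only part of what the source reports. "The series", "measured", "known", "first", "only" and "open" are said of these compounds alone.

Working notes on a small series built around one shared core.

Compound 1 `O=C(/C=C/c1ccc(OCc2cn(Cc3cccc(Br)c3)nn2)cc1)c1ccc(Br)cc1` gives 36% in a functional assay on MCF7 cells (Homo sapiens) for inhibition, read by MTT assay, with a stated time of 48 h, tested at 10 uM; a higher number here means more inhibition of growth at the concentration tested, a lower number less inhibition of growth. Compound 2 `O=C(/C=C/c1ccc(OCc2cn(Cc3ccc(Br)cc3)nn2)cc1)c1ccc(Br)cc1` differs from compound 1 in one place: 4-bromophenyl in place of 3-bromophenyl on a saturated chain carbon bound to an aromatic nitrogen. In this assay compound 2 gives 23%, and the step reads a number 13 percentage points lower from compound 1 to compound 2 (beyond the scatter). Compound 3 `COc1ccc(C(=O)/C=C/c2ccc(OCc3cn(Cc4cccc(Br)c4)nn3)cc2)cc1` differs from compound 1 in another place: methoxy in place of bromo on an aromatic carbon. In this assay compound 3 gives 45%; the step of a number 9 percentage points higher from compound 1 to compound 3 (within the scatter) stays within the scatter, so compound 1 and compound 3 cannot be ordered, while the gap from compound 3 down to compound 2 is beyond it.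

Compound 4 `COc1ccc(C(=O)/C=C/c2ccc(OCc3cn(Cc4ccc(Br)cc4)nn3)cc2)cc1` is not yet measured. Its difference from compound 3 is 4-bromophenyl in place of 3-bromophenyl on a saturated chain carbon bound to an aromatic nitrogen; the place is described in the same words as for the pair compound 1 and compound 2, so this is the same change, now made on the core of compound 3 rather than on the core of compound 1. Among the compounds with values here, only one instance of the change is measured so far, the modest loss of a number 13 percentage points lower from compound 1 to compound 2 (beyond the scatter). On that basis alone, a step of about a number 13 percentage points lower from compound 3 to compound 4 (beyond the scatter) is expected in this assay, so compound 4 is estimated at 32%, between 20% and 44%.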

Compound 4, percent growth inhibition at one concentration: 53%
Beside the measured number, compound 4's estimate is 21 percentage points below it, and the stated range ends below it.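

In this assay, 4-bromophenyl in place of 3-bromophenyl reads a number 8 percentage points higher from compound 3 to compound 4 (within the scatter), so the loss seen on the core of compound 1 does not carry over to the core of compound 3: the same change on two cores in this assay, a number 13 percentage points lower (beyond the scatter) from compound 1 to compound 2 and a number 8 percentage points higher (within the scatter) from compound 3 to compound 4, 21 percentage points apart, beyond the scatter of two such steps. Methoxy in place of bromo on an aromatic carbon reads a number 30 percentage points higher from compound 2 to compound 4 (beyond the scatter), so that change also depends on the core carrying it: the same change on two cores in this assay, a number 9 percentage points higher (within the scatter) from compound 1 to compound 3 and a number 30 percentage points higher (beyond the scatter) from compound 2 to compound 4, 21 percentage points apart, beyond the scatter of two such steps. Both gaps come from the same four compounds and so record one non-additive result rather than two independent ones; they show that neither step can be carried over unchanged within this set, but not why, nor how either change would behave on a further core.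

From the compounds shown here alone, it remains open whether an amine or a hydroxyl group in place of methoxy on that aromatic carbon would show the same dependence on the bromophenyl group. Going by these compounds, it also remains open how a plain phenyl or a chlorophenyl group would read in place of the bromophenyl groups on either core.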